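Side chain exchange on the shared core: compound 2 to compound 4

The compounds below may be only part of what the source reports. "The series", "measured", "known", "first", "only" and "open" are said of these compounds alone.

Values in a toxicity assay on L02 cells (Homo sapiens) for cytotoxicity, read by MTT assay, with a stated time of 72 h; a lower number here means a stronger inhibitor, a higher number a weaker inhibitor:
- compound 1 `CC1(C)OCC(Cn2cc(Cn3c4c(c5ccccc53)C(=O)c3c[n+]([O-])c5ccccc5c3C4=O)nn2)O1`: 120 nM
- compound 2 `O=C1c2c[n+]([O-])c3ccccc3c2C(=O)c2c1c1ccccc1n2Cc1cn(CC(O)CO)nn1`: 1070 nM
- compound 3 `CC1(C)OC[C@@H](Cn2cc(Cn3c4c(c5ccccc53)C(=O)c3c[n+]([O-])c5ccccc5c3C4=O)nn2)O1`: 2900 nM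

Of these three numbers, compound 2 at 1070 nM is the second highest. Compound 4 `CN1CCN(CCCn2c3c(c4ccccc42)C(=O)c2c[n+]([O-])c4ccccc4c2C3=O)CC1` differs from it as follows: 2-(4-methylpiperazin-1-yl)ethyl in place of 1-(2,3-dihydroxypropyl)-1H-1,2,3-triazol-4-yl on a saturated chain carbon bound to an aromatic nitrogen. In words, 2-(4-methylpiperazin-1-yl)ethyl replaces 1-(2,3-dihydroxypropyl)-1H-1,2,3-triazol-4-yl on a saturated chain carbon bound to an aromatic nitrogen.

The closest measured changes are confined to the end of this substituent and were modest: an 8.9-fold higher number from compound 1 to compound 2 (0.95 log units; beyond the scatter) and a 2.7-fold higher number from compound 2 to compound 3 (0.43 log units; beyond the scatter). The large 24-fold higher number from compound 1 to compound 3 (1.38 log units; beyond the scatter) comes with the fact that one of compounds 1 and 3 is drawn with a defined configuration and the other without, at the place where they differ, so it gives a poor scale for this change. None of these steps replaces the whole substituent, so they offer only rough guidance. Compound 2 at 1070 nM lies towards the top of the measured span, so a lower number is the expected direction in this assay. The estimated change is a 2.1-fold lower number from compound 2 to compound 4 (0.33 log units; beyond the scatter), a modest step. For compound 4 the expected value is 500 nM, with an estimated range of 80 nM to 3000 nM.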

Compound 4, half-maximal inhibitory concentration: 230 nM
Beside the measured number, compound 4's estimate is 2.2-fold (0.34 log units) above it, and the stated range covers the measured number.
By their numbers in this assay, from the lowest: compounds 1 and 4 (each within the scatter of the next); then compound 2; then compound 3.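

Exchanging the whole substituent on a saturated chain carbon bound to an aromatic nitrogen gives, in this assay, a 4.7-fold lower number from compound 2 to compound 4 (0.67 log units; beyond the scatter), so a low number at this place does not depend on the 1-(2,3-dihydroxypropyl)-1H-1,2,3-triazol-4-yl group. Compound 4, with 3-(4-methylpiperazin-1-yl)propyl and no triazole ring, stands within the scatter of compound 1, which keeps the triazole ring, so two quite different substituents reach the same level here. Nothing measured for these compounds accounts for this step.

The two substituents differ in ring, chain and hydrogen-bond donor count all at once, so the compounds shown leave open which of these differences matters. A 3-(dimethylamino)propyl or 3-(morpholin-4-yl)propyl group at this place would begin to separate the ring from the terminal amine.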